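The source may hold more compounds than are shown below. What is called first, only, known or untested is meant among the compounds shown, and "the series" means these compounds.

Compound 1 `Cc1cc(C)c(CN2CCc3c(Cl)cc([C@H](CO)[C@@H]4CCCO4)c(Cl)c3C2=O)c(=O)[nH]1` is one of three close relatives that share a core carrying two chloro groups and a side chain ending in a hydroxymethyl. Within the data shown here, in a physicochemical assay for lipophilicity, at pH 7.4 (a lower number here means a more polar compound, a higher number a more lipophilic compound), compound 1 gives 2.4, and that is its single reading, whereas its two relatives were measured repeatedly: compound 2 `COC(c1cc(Cl)c2c(c1Cl)C(=O)N(Cc1c(C)cc(C)[nH]c1=O)CC2)C1CCOC1` gives 3; 3; 3; 3 (4 entries) across four runs, and compound 3 `Cc1cc(C)c(CN2CCc3c(Cl)cc(C(CO)C4CCOC4)c(Cl)c3C2=O)c(=O)[nH]1` gives 2.1; 2.1 (2 entries) across two. Compound 4 `Cc1cc(C)c(CN2CCc3c(Cl)cc([C@H](C)CO)c(Cl)c3C2=O)c(=O)[nH]1` has not yet been measured. It differs from compound 1 in one place: a group of 4 heavy atoms (3 carbon, 1 oxygen; no ring) in place of a group of 8 heavy atoms (6 carbon, 2 oxygen; one five-membered non-aromatic ring with 1 hetero atom), on an aromatic carbon. Among the measured compounds shown here, no measured pair in this set isolates the same change, so the direction must be estimated. Compound 4 is expected to sit a little lower, a step of a number 0.30 log units lower from compound 1 to compound 4 (within the scatter) that barely clears the scatter, giving an estimated 2.1 with a range from 1.6 to 2.6.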

Compound 4, distribution coefficient: 2.6
Compound 4: middle estimate off by 0.50 log units, on the low side, and the stated range covers the measured number.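

In this assay the swap of the group with the five-membered ring for 1-(hydroxymethyl)ethyl on this aromatic carbon gives a number 0.20 log units higher from compound 1 to compound 4 (within the scatter) and so stays inside the usual spread of repeat readings. The ring can therefore go from this position without a clear shift in this read-out. Still open, on these data alone, is whether a chain ending in an amine or a carboxylic acid on this carbon would give a step beyond the scatter, and whether the opposite stereocentre in 1-(hydroxymethyl)ethyl would read the same. Nothing measured here accounts for the result.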